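Swapping bromo for iodo on an aryl thiosemicarbazone

The source may hold more compounds than are shown below. What is called first, only, known or untested is meant among the compounds shown, and "the series" means these compounds.

Compound 1 `Cc1cccc(NC(=S)N/N=C2\C(=O)Nc3ccc([N+](=O)[O-])cc32)c1` gives 10% in a functional assay on the whole organism for inhibition, with Lemna aequinoctialis as the target, tested at 10 ug/mL; on this read-out lower numbers stand for less inhibition of growth and higher numbers for more inhibition of growth at the one concentration tested.
Compound 2 `O=C1Nc2ccc([N+](=O)[O-])cc2/C1=N/NC(=S)Nc1ccc(Br)cc1` gives 10% in this assay.

Compound 2 stands level with compound 1 in this assay; the step of no change at the digits printed from compound 1 to compound 2 (within the scatter) stays within the scatter. Compound 3 `O=C1Nc2ccc([N+](=O)[O-])cc2/C1=N/NC(=S)Nc1ccc(I)cc1` differs from compound 2 by iodo in place of bromo on an aromatic carbon. Going by the values given here, the only measured step touches the same aryl ring and moved nothing beyond the scatter, so no step beyond the scatter is expected in this assay here either. Compound 3 is therefore estimated at 10%, between 0% and 25%, an expected step of no change at the digits printed from compound 2 to compound 3 (within the scatter).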

Compound 3, percent growth inhibition at one concentration: 5%
Compound 3: the middle estimate sits 5 percentage points above what was measured; the measured number falls inside the stated range.
By their numbers in this assay, from the lowest: compounds 3, 1 and 2 (each within the scatter of the next).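

In this assay the halogen on this aromatic carbon can be exchanged without a readable effect: iodo in place of bromo gives a number 5 percentage points lower from compound 2 to compound 3 (within the scatter) and so cannot be told apart from bromo here. Taking 4-iodophenyl in place of 3-methylphenyl gives a number 5 percentage points lower from compound 1 to compound 3 (within the scatter), so all three aryl groups on this nitrogen read alike at the one concentration tested. Nothing at hand explains this result. Still open, going by these compounds, is whether an amine or a carboxylic acid at this place on the ring would move growth inhibition beyond the scatter.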